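This account rests on a few compounds, and the source may have more. Where it says the series, first, only, none or still open, it means among the compounds named here.

Compound 1, `CNS(=O)(=O)c1ccccc1Nc1cc(-c2ccc3ccn(C)c3c2)c2nccnc2c1`, gives > 100000 nM in an assay on lysate for inhibition of 6-phosphofructo-2-kinase/fructose-2,6-bisphosphatase 3 (Homo sapiens), with stated times of 0.5 min and 45 min (on this read-out higher numbers stand for weaker inhibition and lower numbers for stronger inhibition), which is a limit of the assay and not a number.
Compound 2, `CN(Cc1cncnc1)S(=O)(=O)c1ccccc1Nc1cc(-c2ccc3ccn(C)c3c2)c2nccnc2c1`, gives > 100000 nM in this assay, again a limit rather than a number.
Compound 3, `Cn1ccc2ccc(-c3cc(Nc4cnccc4C(=O)NCc4cncnc4)cc4nccnc34)cc21`, gives 49500 nM in this assay.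

Compound 3 therefore stands as the only value that is a number among the three shown; the other two sit at the limit of > 100000 nM in this assay, at which 2 of the 3 values shown sit. Among the compounds with values here, the one step between measured compounds that differ in one place, a step that the two limits leave unreadable from compound 1 to compound 2, rests on two such limits and cannot be read for size, so it tells nothing about how large any change can be here.

Compound 4, `CC(=O)N1CCOC(CNC(=O)c2ccncc2Nc2cc(-c3ccc4ccn(C)c4c3)c3nccnc3c2)C1`, is not yet measured. It differs from compound 3 by 4-acetylmorpholin-2-yl in place of pyrimidin-5-yl on a saturated chain carbon bound to an amide-type nitrogen. Within the data shown here, no measured step touches this kind of change: the only step that exists concerns a sulfonamide nitrogen in compounds 1 and 2 and is itself unreadable. With nothing to lean on, the expectation is that the step of a 1.0-fold higher number from compound 3 to compound 4 (0.00 log units; within the scatter) stays within the usual scatter, with the real chance that compound 4 again returns only a limit. Compound 4 is accordingly estimated at 50000 nM in this assay, with a range from 12000 nM to 200000 nM.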

Compound 4, half-maximal inhibitory concentration: > 100000 nM
Compound 4: a limit, no number (the forecaster's own chance of this, stated with the estimate: 40%); at least 2.0-fold (0.30 log units) between middle value and limit.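

In this assay, within the data shown here, the swap of pyrimidin-5-yl for 4-acetylmorpholin-2-yl on a saturated chain carbon bound to an amide-type nitrogen gives the first step with a readable floor, an at least 2.0-fold higher number from compound 3 to compound 4 (0.30 log units; that floor lies within the scatter). Among these compounds, the earlier step at the sulfonamide nitrogen cannot be read, so this is the first sign of how the series responds to a change, and here a non-aromatic ring carrying an acetyl group brings no lower number than the aromatic ring it replaces, although that floor alone does not establish a real loss. The value of compound 4 is a limit and not a number, and it joins those of compounds 1 and 2: the limit of > 100000 nM in this assay, at which 3 of the 4 values shown sit.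

Among the compounds shown here, how far the true value of compound 4 lies from that of compound 3 remains open, and compound 3 is still the only compound with a number to compare against. The compounds shown also leave open whether a different group on this chain, such as a plain phenyl ring, a primary amine or a carboxylic acid, would give a lower number in this assay.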